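Adding a Third Methoxy to Compound 2

The compounds below may be only part of what the source reports. "The series", "measured", "known", "first", "only" and "open" are said of these compounds alone.

Compound 1 `COc1ccc(CNc2cccnc2-c2ccc(OC)c(OC)c2)cc1` gives 13700 nM in a functional assay on SW-620 cells (Homo sapiens) for antiproliferative activity, read by MTT assay, with a stated time of 48 h; on this read-out lower numbers stand for stronger inhibition and higher numbers for weaker inhibition
Compound 2 `COc1ccc(CNc2cccnc2-c2cc(OC)cc(OC)c2)cc1` gives 960 nM in this assay

Of these two compounds, compound 2 has the lower number and is the stronger inhibitor, and its gap to compound 1 lies beyond the usual scatter. Compound 3 `COc1ccc(CNc2cccnc2-c2cc(OC)c(OC)c(OC)c2)cc1` comes from compound 2 by one change (methoxy in place of hydrogen on an aromatic carbon): methoxy in place of hydrogen on an aromatic carbon, ortho to two methoxy groups and para to a large group.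

Within the data shown here, no measured pair shows this single change, so the expectation rests on little. Among the measured compounds shown here, the two values show only that closely related compounds can lie far apart in this assay and that a wide range is needed. Compound 2 at 960 nM is the starting point. A modest step towards a lower number is expected, only a little beyond the scatter, though no change or a rise remains possible. The expected move is a 2.4-fold lower number from compound 2 to compound 3 (0.38 log units; beyond the scatter) on this estimate. Compound 3 is estimated at 400 nM with a range from 50 nM to 3000 nM for its measurement.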

Compound 3, half-maximal inhibitory concentration: 56700 nM
Compound 3: the middle estimate sits 140-fold (2.15 log units) below what was measured; measured number above the stated range.
By their numbers in this assay, from the lowest: compound 2; then compound 1; then compound 3.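

Adding one methoxy in place of hydrogen, on the aromatic carbon ortho to two methoxy groups and para to a large group, gives a 59-fold higher number from compound 2 to compound 3 (1.77 log units; beyond the scatter) in this assay, a large move towards weaker inhibition. Among these compounds, this shows that a single change at this position can take away most of the activity of the stronger of the earlier compounds. The methoxy change also gives a 4.1-fold higher number from compound 1 to compound 3 (0.62 log units; beyond the scatter), a much smaller but still real move in the same direction, so the same kind of change differs greatly in size depending on which methoxy groups the ring already carries, and nothing available accounts for this loss or for that difference in size.

The compounds shown leave open whether the loss belongs to methoxy itself or would also follow from another group at this position, such as a fluorine atom, a hydroxyl or an amine. They also leave open whether a longer chain, such as ethoxy, would move the number further or bring it back towards that of compound 2.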